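From 3-methoxyphenyl to 6-methoxypyridin-3-yl in the series

The compounds below may be only part of what the source reports. "The series", "measured", "known", "first", "only" and "open" are said of these compounds alone.

In a functional assay on A549 cells (Homo sapiens) for antiproliferative activity, read by MTT assay, with a stated time of 72 h (a lower number here means a stronger inhibitor, a higher number a weaker inhibitor), compound 1 `CC/C=C/C(=O)Nc1cccc(Oc2nc(Nc3cccc(OC)c3)nc3c2CSCC3)c1` gives 17200 nM and compound 2 `CCC/C=C/C(=O)Nc1cccc(Oc2nc(Nc3cccc(OC)c3)nc3c2CSCC3)c1` gives 11800 nM. These two values lie within the scatter of each other, so compound 2 holds no distinct rank and serves here simply as the reference point.

Compound 3 `CCC/C=C/C(=O)Nc1cccc(Oc2nc(Nc3ccc(OC)nc3)nc3c2CSCC3)c1` keeps the chain of compound 2 and exchanges one group: 6-methoxypyridin-3-yl in place of 3-methoxyphenyl on a nitrogen on an aromatic ring. In words, this is 6-methoxypyridin-3-yl in place of 3-methoxyphenyl on a nitrogen on an aromatic ring.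

For the measured compounds named here, the only measured step is a 1.5-fold lower number from compound 1 to compound 2 (0.16 log units; within the scatter). It concerns methyl in place of hydrogen on a saturated chain carbon, not the group on this nitrogen, so the data give no direct size for the present exchange. With only a 1.5-fold lower number from compound 1 to compound 2 (0.16 log units; within the scatter) as a guide, no step beyond the scatter is expected, in either direction, though with wide uncertainty. The estimated change is a 1.0-fold higher number from compound 2 to compound 3 (0.01 log units; within the scatter). For compound 3 the expected value is 12000 nM, with an estimated range of 5000 nM to 30000 nM.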

Compound 3, half-maximal inhibitory concentration: 10800 nM
Beside the measured number, compound 3's estimate is 1.1-fold (0.05 log units) above it; measured number inside the range.
By their numbers in this assay, from the lowest: compounds 3, 2 and 1 (each within the scatter of the next).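

Working notes on the nitrogen substituent: in this assay, the exchange of 3-methoxyphenyl for 6-methoxypyridin-3-yl gives a 1.1-fold lower number from compound 2 to compound 3 (0.04 log units; within the scatter), the only size shown for a change at this position, as the earlier step concerned the chain. The exchange keeps the count of 8 heavy atoms and raises the hydrogen-bond acceptors from 1 to 2, and at this level of activity, with compound 3 at 10800 nM, it produces no step beyond the scatter. No measurement available here bears on why the two compounds read alike.

The compounds shown leave open whether the same exchange would read the same on the shorter chain of compound 1, as this pair carries only the chain of compound 2. Also open, from the compounds shown here alone, is whether a different group on this nitrogen, such as an unsubstituted phenyl, or a dimethylamino group or a carboxylic acid in place of the methoxy, would give a step beyond the scatter in this assay.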